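Extending the Alkoxy Chain Toward a Terminal Acid

A few compounds are considered here, and "the series" means these few. Any claim that something is new, unique, unknown or untested is made for them only; others in the source may bear on it.

Of the compounds shown here, two sharing one core have been measured in an assay (Cricetulus griseus) for inhibition of aldehyde dehydrogenase, mitochondrial (Homo sapiens); on this read-out lower numbers stand for stronger inhibition and higher numbers for weaker inhibition. Compound 2, `CCOc1ccc2c(=O)c(-c3ccc(O)cc3)coc2c1`, stands lowest of the two numbers: compound 2 gives 80 nM. Compound 1, `CCCCCCOc1ccc2c(=O)c(-c3ccc(O)cc3)coc2c1`, carries a longer chain on the aromatic oxygen, and compound 1 gives 1500 nM. For the measured compounds named here, the single measured step, a 19-fold lower number from compound 1 to compound 2 (1.27 log units; beyond the scatter), is large and shows that taking away a butyl from the chain brought the number far down.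

Compound 3, `O=C(O)CCCCCCCOc1ccc2c(=O)c(-c3ccc(O)cc3)coc2c1`, remains to be measured. It differs from compound 2 by 5-carboxypentyl in place of hydrogen on a saturated chain carbon, two bonds along the chain from an oxygen on an aromatic ring, so the chain grows again and now ends in a carboxylic acid. Going by the values given here, the only step that bears on this change is a 19-fold lower number from compound 1 to compound 2 (1.27 log units; beyond the scatter), read in reverse: adding chain length raised the number strongly. Among the compounds with values here, compound 3 carries even more chain than compound 1 did, plus an acid whose effect no measured pair reveals. The expectation for compound 3 is therefore a rise of about a 19-fold higher number from compound 2 to compound 3 (1.27 log units; beyond the scatter) in this assay. The estimate for compound 3 is 1500 nM, expected to fall between 300 nM and 8000 nM.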

Compound 3, half-maximal inhibitory concentration: 40 nM
Compound 3: middle estimate off by 38-fold (1.57 log units), on the high side; measured number outside the range, below it.
By their numbers in this assay, from the lowest: compounds 3 and 2 (each within the scatter of the next); then compound 1.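

In this assay, 5-carboxypentyl in place of hydrogen on the saturated chain carbon, two bonds along the chain from the oxygen on the aromatic ring, gives a 2.0-fold lower number from compound 2 to compound 3 (0.30 log units; within the scatter) and so leaves the number where it was, although the chain is much longer. Carboxymethyl in place of hydrogen on the saturated chain carbon, six bonds along the chain from that oxygen, gives a 38-fold lower number from compound 1 to compound 3 (1.57 log units; beyond the scatter) and is a large step, which shows that what stands at the far end of the chain can matter as much as the length of the chain. Compound 3 therefore goes against the trend suggested by compound 1 and compound 2, and the high number of compound 1 cannot be read as a simple penalty for chain length at this position.

No measurement shown here offers an explanation for this result.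

The compounds shown leave open how a shorter chain ending in a carboxylic acid would read, and whether a longer chain without the carboxylic acid would stay high like compound 1. From the compounds shown here alone, it also remains open whether a methyl ester or an amide at the chain end could stand in for the carboxylic acid.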